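Methyl in Place of Hydrogen on Compound 2

The compounds below may be only part of what the source reports. "The series", "measured", "known", "first", "only" and "open" are said of these compounds alone.

Compound 1, `S=C(Nc1ccccc1)Nc1ccc2[nH]ccc2c1`: 60000 nM
Compound 2, `Oc1ccccc1NC(=S)Nc1ccc2[nH]ccc2c1`: 4000 nM
Compound 3, `COc1ccc(NC(=S)Nc2ccc3[nH]ccc3c2)cc1`: 37000 nM

In an assay on cells for inhibition of Amine oxidase [flavin-containing] B (Homo sapiens), read by spectrophotometry (a higher number here means a weaker inhibitor, a lower number a stronger inhibitor), compound 2 gives the lowest of the three numbers, with compound 3 and compound 1 both beyond the scatter above it. Compound 4, `Cc1ccc(NC(=S)Nc2ccc3[nH]ccc3c2)c(O)c1`, differs from compound 2 by methyl in place of hydrogen on an aromatic carbon. For the measured compounds named here, no measured step adds a methyl group. The two steps known both start from compound 1: a 15-fold lower number from compound 1 to compound 2 (1.18 log units; beyond the scatter) was large, whereas a 1.6-fold lower number from compound 1 to compound 3 (0.21 log units; within the scatter) stayed within the scatter. Neither bears directly on adding a methyl group to compound 2, so the expected step of no change at the digits printed from compound 2 to compound 4 (within the scatter) is none beyond the scatter. Compound 4 is therefore estimated at 4000 nM, with a range from 1500 nM to 11000 nM.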

Compound 4, half-maximal inhibitory concentration: 3200 nM
For compound 4 the middle estimate is 1.3-fold (0.10 log units) above the measured one; low and high end bracket the measured number.
By their numbers in this assay, from the lowest: compounds 4 and 2 (each within the scatter of the next); then compounds 3 and 1 (each within the scatter of the next).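

In this assay the change gives a 1.3-fold lower number from compound 2 to compound 4 (0.10 log units; within the scatter) and so leaves the number of compound 2 in place. For the compounds shown here, an aromatic carbon meta to a hydroxy group and para to a large group therefore accepts methyl in place of hydrogen, which the earlier compounds, all lacking a group there, could not show. Nothing available explains this outcome.

On these data alone, whether an ethyl group, a longer chain, an amine or a carboxylic acid would be accepted at this position stays open. So does whether methyl here gives the same result without the hydroxy group.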